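A few compounds are considered here, and "the series" means these few. Any claim that something is new, unique, unknown or untested is made for them only; others in the source may bear on it.

Compound 1 `Oc1c(C(c2ccc(F)cc2)N2CCCCC2)ccc2nccnc12`: 660 nM
Compound 2 `Cc1ccnc(NC(c2ccc([N+](=O)[O-])cc2)c2ccc3cccnc3c2O)c1`: 530 nM
Compound 3 `Oc1c(C(c2ccc(F)cc2)N2CCCCC2)ccc2scnc12`: 570 nM

All three were tested in an assay for inhibition of protein disulfide-isomerase (Homo sapiens), with a stated time of 1 h; on this read-out lower numbers stand for stronger inhibition and higher numbers for weaker inhibition. Compound 2 gives the lowest of the three numbers, but compound 3 and compound 1 both lie within the usual scatter of it, so the three cannot be ranked. Compound 4 `Cc1ccnc(NC(c2ccc3cccnc3c2O)c2c(Cl)cccc2Cl)c1` has not yet been measured. It differs from compound 2 in one place: 2,6-dichlorophenyl in place of 4-nitrophenyl on a saturated chain carbon bound to an aromatic carbon and a nitrogen on an aromatic ring. For the measured compounds named here, no measured pair in this set shows a change of this kind, so its effect is not known from the data. In this assay the expected step is small, not clearly beyond the scatter, in either direction. Compound 4 is estimated at 700 nM, with a range from 250 nM to 2000 nM. This corresponds to an expected step of a 1.3-fold higher number from compound 2 to compound 4 (0.12 log units; within the scatter).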

Compound 4, half-maximal inhibitory concentration: > 40000 nM
Compound 4 was reported as a limit; the forecaster's own chance of this, stated with the estimate: 5%; at least 57-fold (1.75 log units) between middle value and limit.
By their numbers in this assay, from the lowest: compounds 2, 3 and 1 (each within the scatter of the next). At a limit, above all of these: compound 4.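

In this assay, the group on this saturated chain carbon proves to matter: 2,6-dichlorophenyl in place of 4-nitrophenyl gives an at least 75-fold higher number from compound 2 to compound 4 (1.87 log units; beyond the scatter) in a single change. For the compounds shown here, no pair among the earlier compounds varied this group, and this is the first sign that the position does not accept every substituted phenyl ring. As far as these compounds go, compound 4 stands at a limit, not at a number, and the full size of the step stays unknown: the limit of > 40000 nM in this assay, at which 1 of the 4 values shown sits.

From the compounds shown here alone, whether the loss follows the two chlorines, their place on the ring or the departure of the nitro group remains open. A plain phenyl or a 4-chlorophenyl at this carbon would help to separate these.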